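A few compounds are considered here, and "the series" means these few. Any claim that something is new, unique, unknown or untested is made for them only; others in the source may bear on it.

Of the compounds shown here, three sharing one core have been measured in a functional assay on NCI60 cells (Homo sapiens) for cytotoxicity; on this read-out higher numbers stand for weaker inhibition of growth and lower numbers for stronger inhibition of growth. Compound 1 `O=C1C(N2CCCC2)=CC(=O)c2nc(-c3ccccc3)ccc21` carries a pyrrolidin-1-yl group on the double-bonded ring carbon and gives 44700 nM. Compound 2 `O=C1C=C(NCc2ccccc2)C(=O)c2nc(-c3ccccc3)ccc21` carries a benzylamino group there and gives 33100 nM. Compound 3 `COCCCNC1=CC(=O)c2nc(-c3ccccc3)ccc2C1=O` carries a (3-methoxypropyl)amino group there and gives 3550 nM, the lowest of the three numbers and therefore the strongest growth inhibition among them; compound 2 and compound 1 both sit higher, each beyond the scatter, with compound 1 the furthest away.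

Compound 4 `O=C1C(N2CC2)=CC(=O)c2nc(-c3ccccc3)ccc21` differs from compound 3 in one place: aziridin-1-yl in place of (3-methoxypropyl)amino on a double-bonded ring carbon. Among the measured compounds shown here, the one measured step that bears on this is a 13-fold lower number from compound 1 to compound 3 (1.10 log units; beyond the scatter), where a ring amine without a hydrogen-bond donor was replaced by an open chain bearing one. Compound 4 reverses that direction, going back to a ring amine with no donor, although aziridin-1-yl is a smaller ring than pyrrolidin-1-yl. A move back toward the number of compound 1 is therefore expected, and the step of a 5.6-fold higher number from compound 3 to compound 4 (0.75 log units; beyond the scatter) is expected to be large and upward. Compound 4 is estimated to give 20000 nM, with a range from 5000 nM to 60000 nM.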

Compound 4, concentration for 50% growth inhibition: 27.5 nM
Compound 4: middle estimate off by 730-fold (2.86 log units), on the high side; measured number outside the range, below it.
By their numbers in this assay, from the lowest: compound 4; then compound 3; then compounds 2 and 1 (each within the scatter of the next).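

Placing aziridin-1-yl on the double-bonded ring carbon in this assay gives a 130-fold lower number from compound 3 to compound 4 (2.11 log units; beyond the scatter) and, measured against the larger ring amine, a 1600-fold lower number from compound 1 to compound 4 (3.21 log units; beyond the scatter), so this position can shift the number far more than the first three compounds revealed. An open chain with a hydrogen-bond donor is therefore not needed for a low number here, since aziridin-1-yl, with 0 hydrogen-bond donors, takes the number well under that of the (3-methoxypropyl)amino compound. Having a ring amine at this carbon does not fix the number either: compound 1 and compound 4 both carry one, yet they are separated by the largest step shown, so what the ring is matters greatly, not merely that a ring is there.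

On these data alone, whether this drop belongs to the three-membered ring in particular remains open, and azetidin-1-yl, the four-membered ring amine, or an aziridine bearing a methyl group would show how sharply the number depends on the exact ring. The compounds shown come with no measurement that accounts for the size of this change.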